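Swapping an aromatic amide substituent for a small ring

This account rests on a few compounds, and the source may have more. Where it says the series, first, only, none or still open, it means among the compounds named here.

The compounds here share one core and differ only in the group attached to the amide-type nitrogen. Compound 1 `COc1ccc(CNC(=O)COc2ccc3cc(C(O)(C(F)(F)F)C(F)(F)F)c(O)cc3c2)cc1OC` carries a 3,4-dimethoxybenzyl group on that nitrogen. In an assay on isolated protein for inhibition of receptor-type tyrosine-protein phosphatase C (Homo sapiens), read by spectrophotometry (on this read-out lower numbers stand for stronger inhibition and higher numbers for weaker inhibition), compound 1 gives only a limit, > 20000 nM. Compound 2 `CC(C)c1ccc(NC(=O)COc2ccc3cc(C(O)(C(F)(F)F)C(F)(F)F)c(O)cc3c2)cc1` carries a 4-isopropylphenyl group instead, and in this assay compound 2 gives 7800 nM, the only plain number shown, so it stands as the one measured reference point. Among the measured compounds shown here, the change between them, an at least 2.5-fold lower number from compound 1 to compound 2 (0.40 log units; beyond the scatter), is the single step available for comparison.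

Compound 3 `O=C(COc1ccc2cc(C(O)(C(F)(F)F)C(F)(F)F)c(O)cc2c1)NC1CC1` takes this further: cyclopropyl in place of 4-isopropylphenyl on an amide-type nitrogen. For the measured compounds named here, the only measured step shows that replacing 3,4-dimethoxybenzyl with 4-isopropylphenyl brought the number down from compound 1 to compound 2; it says nothing directly about a cyclopropyl group. Removing the 4-isopropylphenyl that accompanied that improvement makes a weaker result the expectation, so compound 3 is estimated at 20000 nM, with a likely range of 7000 nM to 60000 nM. The expected step of a 2.6-fold higher number from compound 2 to compound 3 (0.41 log units; beyond the scatter) therefore points toward weaker inhibition, and the value may well come back only as a limit.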

Compound 3, half-maximal inhibitory concentration: > 20000 nM
Compound 3 ended at the assay's limit; the forecaster's own chance of this, stated with the estimate: 55%; the middle value lies on the limit itself.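

Exchanging the 4-isopropylphenyl group, with its 9 heavy atoms, for the cyclopropyl group, with 3, weakens inhibition in this assay, with an at least 2.5-fold higher number from compound 2 to compound 3 (0.40 log units; beyond the scatter). Compound 2 is now the only one of the three with a plain number, so a carbon ring on this nitrogen is not enough by itself: the cyclopropyl ring of compound 3 does not keep the activity of compound 2. Compound 3 joins compound 1 at the assay's limit, a limit rather than a true number, so these two cannot be ranked and the step between them cannot be read: the limit of > 20000 nM in this assay, at which 2 of the 3 values shown sit.

From the compounds shown here alone, it remains open how much of the activity of compound 2 depends on the isopropyl group itself, which an unsubstituted phenyl ring on the same nitrogen would begin to show. Also open, going by these compounds, is whether a cyclohexyl ring, a longer chain such as n-butyl, or a phenyl ring carrying a carboxylic acid or an amine would give a plain number in this assay, and on which side of compound 2 at 7800 nM it would fall.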